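This account rests on a few compounds, and the source may have more. Where it says the series, first, only, none or still open, it means among the compounds named here.

Measured compounds:
compound 1 `O=C(Nc1ccc2nc(NC(=O)C3CCCCC3)sc2c1)c1ccc(Br)cc1`
compound 2 `O=C(Nc1ccc2nc(NC(=O)C3CCCCC3)sc2c1)c1c(Cl)cccc1Cl`
compound 3 `O=C(Nc1nc2ccc(NC(=O)C3CCCO3)cc2s1)C1CCCCC1`

In a functional assay on WI-38 VA13 cells (Homo sapiens) for cytotoxicity (a higher number here means that more compound is needed for the effect, a lower number that less compound is needed), compound 1 gives > 4 ug/mL, which is a limit of the assay and not a number. Compound 2 gives 0.015 ug/mL in this assay. Compound 3 gives 1.3 ug/mL in this assay and so holds the higher of the two numbers shown. Among the measured compounds shown here, the one further value is a limit, (the limit of > 4 ug/mL in this assay, at which 1 of the 3 values shown sits). Both measured steps that end at compound 3 concern the group on the carbonyl carbon: an at least 3.0-fold lower number from compound 1 to compound 3 (0.48 log units; beyond the scatter), and an 87-fold higher number from compound 2 to compound 3 (1.94 log units; beyond the scatter).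

Compound 4 `Cc1[nH][n+](C)c(C)c1C(=O)Nc1ccc2nc(NC(=O)C3CCCCC3)sc2c1` differs from compound 3 in a group of 8 heavy atoms (6 carbon, 2 nitrogen; one five-membered aromatic ring with 2 hetero atoms) in place of a group of 5 heavy atoms (4 carbon, 1 oxygen; one five-membered non-aromatic ring with 1 hetero atom), on a carbonyl carbon. For the measured compounds named here, no measured step exchanges a non-aromatic ring for a charged aromatic one at this carbonyl carbon; the steps of an at least 260-fold lower number from compound 1 to compound 2 (2.42 log units; beyond the scatter) and an 87-fold higher number from compound 2 to compound 3 (1.94 log units; beyond the scatter) show only that this position can move the number widely in either direction. Going by the values given here, with no closer precedent, the step expected in this assay is a 1.5-fold higher number from compound 3 to compound 4 (0.19 log units; within the scatter), with wide uncertainty. Compound 4 is estimated at 2 ug/mL, in a range from 0.3 ug/mL to 8 ug/mL.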

Compound 4, half-maximal effective concentration: 0.012 ug/mL
The estimate for compound 4 lay 170-fold (2.22 log units) above the measured number; the whole stated range lies above it.
By their numbers in this assay, from the lowest: compounds 4 and 2 (each within the scatter of the next); then compound 3. At a limit, above all of these: compound 1.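

In this assay, a low number at this carbonyl carbon does not depend on 2,6-dichlorophenyl: the five-membered aromatic ring with net charge +1 gives a 1.3-fold lower number from compound 2 to compound 4 (0.10 log units; within the scatter) and so cannot be told apart from that group. Against oxolan-2-yl, the same ring gives a 110-fold lower number from compound 3 to compound 4 (2.03 log units; beyond the scatter) and shows that this charged group reaches the low end of the series. Compound 1 stands at a limit, not a number, and the step from it is an at least 330-fold lower number from compound 1 to compound 4 (2.52 log units; beyond the scatter), so 4-bromophenyl goes against any reading that an aromatic ring alone is enough.

Open, on these data alone, is whether an aminomethyl or carboxymethyl group on this carbonyl carbon would also stay at the low end. Nothing in the data shown accounts for these steps.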